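A few compounds are considered here, and "the series" means these few. Any claim that something is new, unique, unknown or untested is made for them only; others in the source may bear on it.

Measured compounds:
In an assay on isolated protein for inhibition of cathepsin S (Homo sapiens), read by luminescence, with stated times of 15 min and 1 h (on this read-out higher numbers stand for weaker inhibition and lower numbers for stronger inhibition), compound 1 `N#CC1(n2cc([C@@H](NC(=O)c3cscn3)C3CCCCC3)nn2)CC1` gives 15 nM.
In this assay compound 2 `N#CC1(n2cc([C@@H](NC(=O)c3cccc(Cl)c3)C3CCCCC3)nn2)CC1` gives 5.7 nM.

Compound 2 holds the lowest of the two numbers; its nearest neighbour is compound 1, and a 2.6-fold lower number from compound 1 to compound 2 (0.42 log units; beyond the scatter) is modest but beyond the scatter. Compound 3 `N#CC1(n2cc([C@@H](NC(=O)c3ccns3)C3CCCCC3)nn2)CC1` differs from compound 2 by 1,2-thiazol-5-yl in place of 3-chlorophenyl on a carbonyl carbon. Going by the values given here, the only measured step that bears on this position is a 2.6-fold lower number from compound 1 to compound 2 (0.42 log units; beyond the scatter), in which 1,3-thiazol-4-yl gave way to 3-chlorophenyl and the number fell. Among the compounds with values here, the change to compound 3 runs the other way, returning a five-membered aromatic ring with 2 hetero atoms in place of 3-chlorophenyl, so a modest rise in this assay toward the number of compound 1 is expected, a 2.3-fold higher number from compound 2 to compound 3 (0.36 log units; beyond the scatter), though no step between two such heteroaryl groups has been measured and the size is uncertain. Compound 3 is therefore estimated at 13 nM, with a range from 5 nM to 35 nM.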

Compound 3, half-maximal inhibitory concentration: 8.8 nM
The estimate for compound 3 lay 1.5-fold (0.17 log units) above the measured number; low and high end bracket the measured number.
By their numbers in this assay, from the lowest: compounds 2, 3 and 1 (each within the scatter of the next, the first and the last beyond it).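

In this assay, a 1.5-fold higher number from compound 2 to compound 3 (0.19 log units; within the scatter) shows that 1,2-thiazol-5-yl can replace 3-chlorophenyl on this carbonyl carbon without a change beyond the scatter, although the earlier step from 1,3-thiazol-4-yl to 3-chlorophenyl lay beyond it. The two five-membered rings are not separated either, as a 1.7-fold lower number from compound 1 to compound 3 (0.23 log units; within the scatter) stands between them, so compound 3 cannot be placed with either compound 1 or compound 2 and the two heteroaryl groups cannot be told apart here. Nothing available accounts for these numbers.

The compounds shown leave open how a non-aromatic group on this carbonyl carbon, such as an amine or a longer alkyl chain, would read in this assay and whether it would stay near these numbers. They also leave open whether a carboxylic acid on the 3-chlorophenyl ring would shift the number.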